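The source may report more compounds than this note shows. Statements on the series, on what has been measured and on what is new or still open speak of the compounds shown alone.

Compound 1, `Cc1nc(N)sc1CCCN/C(N)=N/C(=O)NC(C)c1ccc(Br)cc1`, gives 0.87 in a functional assay on Right cardiac atrium for agonist activity at histamine H2 receptor (Cavia porcellus), with a stated time of 30 min, in the presence of a further agent that is not named here; a higher number here means a larger maximal response, a lower number a smaller maximal response.
Compound 2, `Cc1nc(N)sc1CCCN/C(N)=N/C(=O)N[C@@H](C)c1ccccc1`, gives 1.08 in this assay.
Compound 3, `Cc1nc(N)sc1CCCN/C(N)=N/C(=S)N[C@H](C)c1ccccc1`, gives 0.87 in this assay.

Three compounds share a core and differ only in the group carried on the saturated chain carbon that bears the amide-type nitrogen and in the carbonyl or thiocarbonyl beside it. In this assay compound 1 stands level with compound 3 at the digits printed, the two together forming the lowest of the three numbers, and the pair lies within the usual scatter of each other. Compound 2 stands highest, a number well above compound 1 and beyond the scatter.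

Compound 4, `Cc1nc(N)sc1CCCN/C(N)=N/C(=O)NC(C)c1cccc(F)c1`, has not yet been measured. It differs from compound 1 in one place: 3-fluorophenyl in place of 4-bromophenyl on a saturated chain carbon bound to an amide-type nitrogen and a saturated chain carbon. Among the compounds with values here, no pair of measured compounds differing in this single place is available, so the expected step rests only on the spread seen across compounds 1, 2 and 3, which is modest. The step expected is a number 0.050 higher from compound 1 to compound 4 (within the scatter), a small rise, within the scatter, in this assay. Compound 4 is therefore estimated at 0.92, with a range from 0.75 to 1.1.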

Compound 4, intrinsic activity: the largest response reached, as a fraction of the reference agonist's: 0.85
Beside the measured number, compound 4's estimate is 0.070 above it, and the stated range covers the measured number.
By their numbers in this assay, from the lowest: compounds 4, 1 and 3 (each within the scatter of the next); then compound 2.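

In this assay, within the data shown here, 3-fluorophenyl in place of 4-bromophenyl on a saturated chain carbon bound to an amide-type nitrogen and a saturated chain carbon gives a number 0.020 lower from compound 1 to compound 4 (within the scatter) and so provides the first pair that differs in this single place. It shows that the maximal response stays within the scatter when one halogen-bearing phenyl group is exchanged for the other, so this particular change leaves the read-out effectively unmoved, although one pair cannot show how far that holds for other groups at this position. Nothing measured here bears on the reason for this result.

The step changes the halogen and its place on the ring together, so this pair cannot separate the contribution of either one. From the compounds shown here alone, it also remains open whether a group of another kind on that ring, such as a carboxylic acid, an amine or a methoxy group, would leave the maximal response similarly unchanged.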